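The source may report more compounds than this note shows. Statements on the series, on what has been measured and on what is new or still open speak of the compounds shown alone.

Working notes on the series. In a functional assay on A549 cells (Homo sapiens) for inhibition, read by CCK-8 assay, with a stated time of 72 h, tested at 8 uM (on this read-out higher numbers stand for more inhibition of growth at the one concentration tested and lower numbers for less inhibition of growth), compound 1 (`COc1ccc(SCc2ccc(C(=O)Nc3ccccc3N)cc2)cc1`) gives 70.7%. That places compound 1 within the scatter of compound 3 (`COc1ccc(SCc2ccc(C(=O)Nc3ccccc3N)cc2)cc1OC`), at 80.1%, and well above compound 2 (`Cc1ccc(SCc2ccc(/C=C/C(=O)Nc3ccccc3N)cc2)cc1`), at 48.3%. Compound 2 differs from compound 1 in more than one place, so it offers no clean single-change comparison.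

Compound 4 (`Cc1cc(C)cc(SCc2ccc(C(=O)Nc3ccccc3N)cc2)c1`) is the next case, with 3,5-dimethylphenyl in place of 4-methoxyphenyl on a sulfur. The rest of the core of compound 1 stays the same.

Among the measured compounds shown here, only one measured step bears on this change: a number 9.4 percentage points higher from compound 1 to compound 3 (within the scatter), for methoxy in place of hydrogen on an aromatic carbon. It concerns the same aromatic ring on the sulfur, but it is a single step and does not test the loss of the methoxy or the entry of two methyl groups. For the measured compounds named here, with only that step as a guide, no shift beyond the scatter is expected in this assay, and no direction can be assigned with confidence.

The expected outcome is a number 0.3 percentage points higher from compound 1 to compound 4 (within the scatter). For compound 4 the estimated value is 71%, with an expected range from 54% to 87%.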

Compound 4, percent growth inhibition at one concentration: 78.5%
Compound 4: the middle estimate sits 7.5 percentage points below what was measured, within the range that was stated.
By their numbers in this assay, from the lowest: compound 2; then compounds 1, 4 and 3 (each within the scatter of the next).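

In this assay, 3,5-dimethylphenyl in place of 4-methoxyphenyl on a sulfur gives a number 7.8 percentage points higher from compound 1 to compound 4 (within the scatter), so this position accepts a full exchange of the aryl group without a change beyond the scatter. The earlier step, a number 9.4 percentage points higher from compound 1 to compound 3 (within the scatter), only showed a methoxy added to a ring that already carried one; this pair shows that the same level of growth inhibition at the one concentration tested is kept with no oxygen on that ring, the entering group counting 0 hydrogen-bond acceptors against 1 for the group that leaves. No measurement on hand explains why these two aryl groups read alike.

Open is how far this tolerance extends, since the aryl groups shown on the sulfur carry only methoxy or methyl, and a ring bearing a dimethylamino group or a carboxylic acid could read quite differently. Also open, on these data alone, is whether compound 1 and compound 4 would stay within the scatter of each other at other concentrations, as a single-concentration read-out cannot settle that.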